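The compounds below may be only part of what the source reports. "The series", "measured", "known", "first", "only" and "open" are said of these compounds alone.

Measured so far:
- Compound 1, `CNc1nc(O)c(Br)c(-c2ccccc2)n1`: 82%
- Compound 2, `Nc1nc(O)c(I)c(-c2ccccc2)n1`: 8%
- Compound 3, `Cn1c(-c2ccccc2)c(Br)c(=O)[nH]c1=O`: 57%

Three compounds sharing a phenyl-bearing core were tested in a functional assay on the whole organism for inhibition, with Rattus norvegicus as the target, at a dose of 100 mg/kg by the oral route; a lower number here means a weaker effect, a higher number a stronger effect of the compound at the dose given. Compound 1 gives 82%, the highest of the three numbers. Its nearest neighbour on the numbers is compound 3, which in this assay gives 57%, a gap beyond the scatter. Compound 2, at 8% in this assay, lies furthest away, again beyond the scatter. Within the data shown here, no step between measured compounds that differ in one place is available, so nothing is known about how a single change at the carbon between the two ring nitrogen atoms shifts the read-out.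

Compound 4, `Oc1nc(O)c(Br)c(-c2ccccc2)n1`, is the next compound. It differs from compound 1 as follows: hydroxy in place of methylamino on an aromatic carbon

Among the measured compounds shown here, with no single-change step to lean on, the account can only note that the three numbers spread widely. The step from compound 1 to compound 4 is expected to be a drop beyond the scatter, a number 37 percentage points lower from compound 1 to compound 4 (beyond the scatter), with wide uncertainty. Compound 4 is therefore estimated at 45% in this assay, within a range from 10% to 80%.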

Compound 4, a percentage reported as inhibition, in the whole organism at one dose (the size of the read-out at that dose, not a potency): 58%
The estimate for compound 4 lay 13 percentage points below the measured number, within the range that was stated.
By their numbers in this assay, from the lowest: compound 2; then compounds 3 and 4 (each within the scatter of the next); then compound 1.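

In this assay, among these compounds, hydroxy in place of methylamino on the aromatic carbon between two ring nitrogen atoms gives a number 24 percentage points lower from compound 1 to compound 4 (beyond the scatter), the first single-change reading at this position. It shows that the group at this place matters to the read-out, even though the two groups match in their counts of hydrogen-bond donors and acceptors. Nothing measured here explains the step.

The compounds shown leave open how dimethylamino, methoxy or a longer chain such as propylamino would read at this position. They also leave open whether the same exchange would give a similar step with a group other than bromo on the shared core.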